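The compounds below may be only part of what the source reports. "The series", "measured", "known", "first", "only" and "open" are said of these compounds alone.

Three analogues sharing one core have been measured in a functional assay on HT-29 cells (Homo sapiens) for cytotoxicity, read by MTT assay, with a stated time of 72 h; a higher number here means a weaker inhibitor, a lower number a stronger inhibitor. Compound 1 `COc1cc2c(Oc3ccc(NC(=O)N/N=C/c4ccc(F)cc4Cl)cc3F)ccnc2cc1OCCCN1CCCCC1` gives 260 nM, compound 2 `COc1ccc(/C=N/NC(=O)Nc2ccc(Oc3ccnc4cc(OCCCN5CCCCC5)c(OC)cc34)c(F)c2)c(OC)c1` gives 1600 nM, and compound 3 `COc1cc2c(Oc3ccc(NC(=O)N/N=C/c4ccc(N(C)C)cc4)cc3F)ccnc2cc1OCCCN1CCCCC1` gives 1000 nM. Compound 3 thus holds the second highest of the three numbers: it sits within the scatter of compound 2, while compound 1 lies clearly lower, the gap being a 3.8-fold higher number from compound 1 to compound 3 (0.59 log units; beyond the scatter).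

Compound 4 `COc1cc2c(Oc3ccc(NC(=O)N/N=C/c4cc5ccccc5[nH]4)cc3F)ccnc2cc1OCCCN1CCCCC1` is not yet measured. It differs from compound 3 in one place: 1H-indol-2-yl in place of 4-(dimethylamino)phenyl on a carbon with a double bond to nitrogen. The measured steps that bear on this are all exchanges of the aryl group on that same carbon: a 6.2-fold higher number from compound 1 to compound 2 (0.79 log units; beyond the scatter), a 3.8-fold higher number from compound 1 to compound 3 (0.59 log units; beyond the scatter) and a 1.6-fold lower number from compound 2 to compound 3 (0.20 log units; within the scatter). Two of these steps were modest and beyond the scatter, one lay within it, so this position is sensitive to the aryl group but not dramatically so.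

Because the exchange in a 3.8-fold higher number from compound 1 to compound 3 (0.59 log units; beyond the scatter) moved the number only modestly, compound 4 is expected to differ from compound 3 by a similarly modest step, a 1.7-fold lower number from compound 3 to compound 4 (0.22 log units; within the scatter), with the direction uncertain. On that basis compound 4 is estimated to give 600 nM in this assay, with a likely range from 200 nM to 2000 nM.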

Compound 4, half-maximal inhibitory concentration: 820 nM
Compound 4: middle estimate off by 1.4-fold (0.14 log units), on the low side; the range from low to high includes it.
By their numbers in this assay, from the lowest: compound 1; then compounds 4, 3 and 2 (each within the scatter of the next).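

The exchange shows that this place tolerates a large change in the aryl group without a readable shift in this assay: the 1H-indol-2-yl group adds a five-membered aromatic ring and a hydrogen-bond donor that 4-(dimethylamino)phenyl lacks, yet the result is a 1.2-fold lower number from compound 3 to compound 4 (0.09 log units; within the scatter), and the comparison with the 2,4-dimethoxyphenyl group gives a 2.0-fold lower number from compound 2 to compound 4 (0.29 log units; within the scatter). The 2-chloro-4-fluorophenyl group of compound 1 therefore remains the only one of the four aryl groups that separates from the others, now also against the indole, with a 3.2-fold higher number from compound 1 to compound 4 (0.50 log units; beyond the scatter), so compounds 2, 3 and 4 form a single group despite their different ring types. Nothing measured here explains why the hydrogen-bond donor of the indole leaves the number within the scatter of the other two compounds, or why compound 1 stands apart.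

The compounds shown leave open whether the lower number of compound 1 comes from its chlorine, its fluorine or the two together, which a plain phenyl, a 2-chlorophenyl or a 4-fluorophenyl group would separate. They also leave open whether the indole ring hydrogen plays any part, which a 1-methylindol-2-yl group would test.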